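The compounds below may be only part of what the source reports. "The series", "measured", "known", "first", "only" and "open" are said of these compounds alone.

Compound 1 `C=CC(=O)Nc1cccc(Nc2nc(Cl)nc(Nc3ccc(OCCOC)cc3)n2)c1` gives "not determined" (no result reported) in a functional assay on Ramos cells (Homo sapiens) for antiproliferative activity, read by CCK-8 assay, with a stated time of 24 h (on this read-out lower numbers stand for stronger inhibition and higher numbers for weaker inhibition), and compound 3 `C=CC(=O)Nc1cccc(Nc2ncnc(Nc3ccc(-c4ccc(C)nc4)cc3)n2)c1` likewise gives "not determined" (no result reported) in this assay, while compound 2 `C=CC(=O)Nc1cccc(Nc2nc(N)nc(Nc3ccc(OCCOC)cc3)n2)c1` gives 18900 nM in this assay. Compound 3 therefore stands without a single number, and the only figure in the set comes from compound 2. Compound 4 `C=CC(=O)Nc1cccc(Nc2ncnc(Nc3ccc(C(=O)N4CCCCC4)cc3)n2)c1` is the next compound to be tested; compared with compound 3 the change is (piperidin-1-yl)carbonyl in place of 6-methylpyridin-3-yl on an aromatic carbon. Going by the values given here, with no measured step between any two compounds, the writer expects the difference from compound 3 to compound 4 in this assay to be of modest size, in either direction, with weak inhibition remaining likely given that compound 2 reaches only 18900 nM. Compound 4 is expected to give about 10000 nM in this assay, within a range from 2000 nM to 50000 nM.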

Compound 4, half-maximal inhibitory concentration: 6140 nM
Beside the measured number, compound 4's estimate is 1.6-fold (0.21 log units) above it; low and high end bracket the measured number.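

In this assay, going by these compounds alone, compound 3 has no single number, so no step to compound 4 can be read. The compounds shown leave open how the (piperidin-1-yl)carbonyl group compares with the 6-methylpyridin-3-yl group. No supporting data bear on this result.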